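The source may hold more compounds than are shown below. What is called first, only, known or untested is meant among the compounds shown, and "the series" means these compounds.

Compound 3 `Cc1cc(Cl)ccc1C(=O)Nc1ccc(Cl)c(-c2nnc3c(Cl)cccn23)c1` is one of three measured compounds that share a common core and differ only in the group attached to the carbonyl carbon. In a functional assay on AN3-CA cells (Homo sapiens) for antiproliferative activity, read by MTT assay, with a stated time of 72 h (on this read-out lower numbers stand for stronger inhibition and higher numbers for weaker inhibition), compound 3 gives > 100000 nM, which is a limit of the assay and not a number. Compound 1 `Cc1nc(C(=O)Nc2ccc(Cl)c(-c3nnc4c(Cl)cccn34)c2)cs1` in this assay gives > 100000 nM, again a limit. Compound 2 `CS(=O)(=O)c1ccc(C(=O)Nc2ccc(Cl)c(-c3nnc4c(Cl)cccn34)c2)cc1` in this assay gives > 100000 nM, also a limit. Because of the limit of > 100000 nM in this assay, at which 3 of the 3 values shown sit, the steps among these three cannot be sized: a step that the two limits leave unreadable from compound 1 to compound 2, a step that the two limits leave unreadable from compound 1 to compound 3 and a step that the two limits leave unreadable from compound 2 to compound 3 all remain unreadable. Compound 4 `O=C(Nc1ccc(Cl)c(-c2nnc3c(Cl)cccn23)c1)c1ccc(Cl)cc1Cl` has not yet been measured in this assay. It differs from compound 3 in one place: chloro in place of methyl on an aromatic carbon. Among the compounds with values here, none of the measured steps concerns this change, and none of them offers a readable size that could be carried over. There is therefore no footing for expecting a step beyond the scatter in either direction, and the step from compound 3 to compound 4 is estimated as a number no higher from compound 3 to compound 4 (the limit leaves the size open). Compound 4 is accordingly expected to give 100000 nM, within 30000 nM to 300000 nM, with a real chance that this assay again reports only a limit.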

Compound 4, half-maximal inhibitory concentration: 84800 nM
Beside the measured number, compound 4's estimate is 1.2-fold (0.07 log units) above it; low and high end bracket the measured number.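

Within the data shown here, compound 4 is the first compound here to give a number and not a limit in this assay, so chloro in place of methyl on an aromatic carbon, ortho to a large group, has a step that can be read, if only as a floor: an at least 1.1-fold lower number from compound 3 to compound 4 (0.07 log units; that floor lies within the scatter). The 2,4-dichlorophenyl group gives the same kind of floor against the other two groups on the carbonyl carbon, namely an at least 1.1-fold lower number from compound 2 to compound 4 (0.07 log units; that floor lies within the scatter) and an at least 1.1-fold lower number from compound 1 to compound 4 (0.07 log units; that floor lies within the scatter). The steps among compounds 1, 2 and 3 remain unreadable, because they rest on a limit at both ends: the limit of > 100000 nM in this assay, at which 3 of the 4 values shown sit.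

Going by these compounds, the true size of all three new steps remains open, and so does whether any of them goes beyond the scatter, as only a floor is known for each. The compounds shown also leave open what a methoxy group, an amine or a carboxylic acid would give in place of the chloro on this ring in this assay, and whether any such group would bring the number well clear of the limit.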